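From furan-3-yl to 1-benzofuran-2-yl on the shared core

The source may report more compounds than this note shows. Statements on the series, on what has been measured and on what is new or still open speak of the compounds shown alone.

Going by the values given here, in a functional assay on K562 cells (Homo sapiens), read by MTT assay, with a stated time of 72 h (on this read-out higher numbers stand for weaker inhibition and lower numbers for stronger inhibition), compound 3 `Nc1nc2c(c(-c3ccoc3)cn2[C@@H]2O[C@H](CO)[C@@H](O)[C@H]2O)c(=O)[nH]1` gives 12500 nM, the only true number so far. Compound 1 `Cc1nc(N)c2c(-c3cccs3)cn([C@@H]3O[C@H](CO)[C@@H](O)[C@H]3O)c2n1` reads > 20000 nM, which is a limit of the assay. Compound 2 `C#Cc1cn([C@@H]2O[C@H](CO)[C@@H](O)[C@H]2O)c2nc(N)nc(OC)c12` reads > 20000 nM, which is also a limit. Compound 4 `Nc1nc2c(c(-c3cc4ccccc4o3)cn2[C@@H]2O[C@H](CO)[C@@H](O)[C@H]2O)c(=O)[nH]1` carries 1-benzofuran-2-yl in place of furan-3-yl on an aromatic carbon. Among the compounds with values here, no measured step gauges this change, so no shift beyond the usual scatter in this assay is expected, with any drift toward weaker inhibition. The estimated move is a 1.4-fold higher number from compound 3 to compound 4 (0.16 log units; within the scatter). For compound 4 the expected value is 18000 nM, with an estimated range of 6000 nM to 40000 nM.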

Compound 4, half-maximal inhibitory concentration: > 20000 nM
Compound 4 was reported as a limit; the forecaster's own chance of this, stated with the estimate: 55%; middle value at least 1.1-fold (0.04 log units) away from the limit.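

Compound 4 reads > 20000 nM in this assay, which is a limit of the assay. The first step read at this position is an at least 1.6-fold higher number from compound 3 to compound 4 (0.20 log units; that floor lies within the scatter); it is a floor only, so its true size cannot be read, but adding the six-membered aromatic ring of carbon only brings no value under the limit. Little of the series can now be compared: the limit of > 20000 nM in this assay, at which 3 of the 4 values shown sit.

Going by these compounds, it remains open how far past the limit compound 4 lies. Also open, on these data alone, is what a smaller group, such as an amine or a carboxylic acid, would give on this aromatic carbon.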